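This account rests on a few compounds, and the source may have more. Where it says the series, first, only, none or still open, it means among the compounds named here.

Three compounds share one core, a urea joined through an ether to a pyrimidine carrying a nitrogen substituent. Compound 1 `Cc1ccc(NC(=O)Nc2ccc(Oc3cc(NCc4ccccc4)ncn3)cc2)cc1C(F)(F)F` carries a benzyl group on that nitrogen and in a functional assay on BaF3 cells (Mus musculus) for inhibition, read by CCK-8 assay, with a stated time of 72 h (on this read-out higher numbers stand for weaker inhibition of growth and lower numbers for stronger inhibition of growth), compound 1 gives 3010 nM. Compound 2 `C=CC(=O)Nc1cc(Oc2ccc(NC(=O)Nc3ccc(C)c(C(F)(F)F)c3)cc2)ncn1` carries a vinylcarbonyl there, and in this assay compound 2 gives 1940 nM; the move a 1.6-fold lower number from compound 1 to compound 2 (0.19 log units; within the scatter) is within the scatter. Compound 3 `Cc1ccc(NC(=O)Nc2ccc(Oc3cc(NCCN)ncn3)cc2)cc1C(F)(F)F` carries a 2-aminoethyl group. In this assay compound 3 gives only a limit, > 10000 nM, so it stands at the limit of > 10000 nM in this assay, at which 1 of the 3 values shown sits, and its true number is not known beyond that.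

Compound 4 `CC(=O)Nc1cc(Oc2ccc(NC(=O)Nc3ccc(C)c(C(F)(F)F)c3)cc2)ncn1` differs from compound 3 by acetyl in place of 2-aminoethyl on a nitrogen on an aromatic ring. For the measured compounds named here, the steps that bear on this are an at least 5.1-fold higher number from compound 2 to compound 3 (0.71 log units; beyond the scatter) and an at least 3.3-fold higher number from compound 1 to compound 3 (0.52 log units; beyond the scatter): removing the 2-aminoethyl group in favour of either a vinylcarbonyl or a benzyl gave a lower number by at least a modest amount, so the reverse exchange, toward an acetyl, is expected to bring the number back down. Compound 4 is therefore expected to show an at least 3.3-fold lower number from compound 3 to compound 4 (0.52 log units; beyond the scatter), landing near compound 2, with an estimate of 3000 nM and a range from 1000 nM to 10000 nM.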

Compound 4, concentration for 50% growth inhibition: 3230 nM
Compound 4: middle estimate off by 1.1-fold (0.03 log units), on the low side; the measured number falls inside the stated range.
By their numbers in this assay, from the lowest: compounds 2, 1 and 4 (each within the scatter of the next). At a limit, above all of these: compound 3.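

In this assay, an at least 3.0-fold lower number from compound 3 to compound 4 (0.49 log units; beyond the scatter) shows that an acetyl group on this nitrogen gives a measurable number, even though it holds the same count of heavy atoms as the 2-aminoethyl group it replaces, so that count alone does not separate the two groups. The vinyl group is not required for a number in this range, as methyl in its place on the carbonyl carbon stays within the scatter, a 1.7-fold higher number from compound 2 to compound 4 (0.22 log units; within the scatter), and acetyl in place of benzyl does too, a 1.1-fold higher number from compound 1 to compound 4 (0.03 log units; within the scatter). Compound 3 still gives only a limit, not a number: the limit of > 10000 nM in this assay, at which 1 of the 4 values shown sits.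

On these data alone, the true size of the step from compound 3 therefore stays unknown. As far as these compounds go, it also remains open how a 2-hydroxyethyl group, a longer amine chain or a carboxylic acid on this nitrogen would read.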